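The source may hold more compounds than are shown below. What is called first, only, known or untested is meant among the compounds shown, and "the series" means these compounds.

Compound 1, `COc1cc2ncnc(Nc3cccc(Cl)c3)c2cc1OCCCCC(=O)Nc1ccc(S(N)(=O)=O)cc1`, gives 11200 nM in a functional assay on A549 cells (Homo sapiens) for antiproliferative activity, read by MTT assay, with a stated time of 72 h; a lower number here means a stronger inhibitor, a higher number a weaker inhibitor. Compound 2, `COc1cc2ncnc(Nc3ccc(OC(F)(F)F)cc3)c2cc1OCCCCC(=O)Nc1ccc(S(N)(=O)=O)cc1`, gives only > 40000 nM in this assay, which is a limit of the assay and not a number.

Compound 2 therefore stands at the limit of > 40000 nM in this assay, at which 1 of the 2 values shown sits, the weakest point shown. Among the compounds with values here, the only measured step, an at least 3.5-fold higher number from compound 1 to compound 2 (0.55 log units; beyond the scatter), changed the group on the same ring. Compound 3, `COc1cc2ncnc(Nc3ccccc3)c2cc1OCCCCC(=O)Nc1ccc(S(N)(=O)=O)cc1`, differs from compound 2 by hydrogen in place of trifluoromethoxy on an aromatic carbon. Within the data shown here, no measured step removes a group from this ring, so the direction is open; compound 3 is estimated at 20000 nM, between 7000 nM and 60000 nM, a step of an at least 2.0-fold lower number from compound 2 to compound 3 (0.30 log units; that floor lies within the scatter).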

Compound 3, half-maximal inhibitory concentration: > 40000 nM
Compound 3: a limit, no number; the forecaster's own chance of this, stated with the estimate: 35%; middle value at least 2.0-fold (0.30 log units) away from the limit.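

Taking the ring group away altogether does not bring back a readable number: hydrogen in place of chloro gives an at least 3.5-fold higher number from compound 1 to compound 3 (0.55 log units; beyond the scatter) in this assay. Among the three compounds, then, only compound 1, with its chloro group, gives a number, and the bare phenyl ring of compound 3 does no better than a limit, which is not a number. The step from compound 2 to compound 3 cannot be read: the limit of > 40000 nM in this assay, at which 2 of the 3 values shown sit.

On these data alone, how a fluoro, a methyl or an amine on this ring would read remains open. So does the effect of a longer chain in place of the present one.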